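Amide substituent variation, compound 2 to compound 3

The source may report more compounds than this note shows. Statements on the series, on what has been measured and on what is new or still open speak of the compounds shown alone.

Compound 2 `CCCCNC(=O)CCCOc1ccc(C(=O)c2c(CCCC)oc3ccccc23)cc1` carries a 2-(butylcarbamoyl)ethyl group on a saturated chain carbon bound to an oxygen on an aromatic ring. In a functional assay on HL-60 cells (Homo sapiens) for antiproliferative activity, read by MTT assay, with a stated time of 24 h (a higher number here means a weaker inhibitor, a lower number a stronger inhibitor), compound 2 gives > 50000 nM, which is a limit of the assay and not a number. Compound 1 `CCCCNC(=O)COc1ccc(C(=O)c2c(CCCC)oc3ccccc23)cc1` carries butylcarbamoyl at the same place. In this assay compound 1 gives > 50000 nM, again a limit. The step that the two limits leave unreadable from compound 1 to compound 2 is therefore not readable, and the limit of > 50000 nM in this assay, at which 2 of the 2 values shown sit, is all the series shows so far. Compound 3 `CCCCc1oc2ccccc2c1C(=O)c1ccc(OCCCC(=O)N[C@H](C)c2ccccc2)cc1` is still to be measured; it differs from compound 2 by 1-phenylethyl in place of butyl on an amide-type nitrogen. For the measured compounds named here, no measured step touches the amide nitrogen, so neither size nor direction of the change can be read from the series. Compound 3 is expected to remain near the limit, estimated at 60000 nM (range 15000 nM to 250000 nM), an expected step that the limit leaves unreadable from compound 2 to compound 3.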

Compound 3, half-maximal inhibitory concentration: > 50000 nM
Compound 3: no number, only a limit; the forecaster's own chance of this, stated with the estimate: 70%; the middle value lies beyond the limit too.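

In this assay compound 3 gives > 50000 nM, a limit of the assay and not a number. No step from compound 2 to compound 3 can be read, and the series stays at one limit: the limit of > 50000 nM in this assay, at which 3 of the 3 values shown sit.

From the compounds shown here alone, whether compound 1, compound 2 and compound 3 differ at all in antiproliferative activity remains open.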